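Replacing a Sulfonamide With an Amine on the Shared Core

A few compounds are considered here, and "the series" means these few. Any claim that something is new, unique, unknown or untested is made for them only; others in the source may bear on it.

Measured compounds:
Compound 1 `CN1CCN(CCCN(C(=O)Nc2ccc(F)c(Cl)c2)C2CCc3ccccc3C2)CC1`: 380 nM
Compound 2 `CN1CCN(CCCN(C(=O)Nc2ccc(F)c(Cl)c2)C2CCc3ccc(S(C)(=O)=O)cc3C2)CC1`: 1300 nM
Compound 3 `CNS(=O)(=O)c1ccc2c(c1)CC(N(CCCN1CCN(C)CC1)C(=O)Nc1ccc(F)c(Cl)c1)CC2`: 3000 nM

These three compounds share one core and differ only in the group carried on a single aromatic carbon. In an assay on CHO cells for binding affinity to melanin-concentrating hormone receptor 1 (Homo sapiens) (a higher number here means a weaker inhibitor, a lower number a stronger inhibitor), compound 3 gives the highest number of the three: it sits a 2.3-fold higher number from compound 2 to compound 3 (0.36 log units; beyond the scatter) and a 7.9-fold higher number from compound 1 to compound 3 (0.90 log units; beyond the scatter), both beyond the scatter, so compound 3 is the weakest inhibitor of the set.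

Compound 4 `CN1CCN(CCCN(C(=O)Nc2ccc(F)c(Cl)c2)C2CCc3ccc(N)cc3C2)CC1` has not yet been measured. It differs from compound 3 by amino in place of methylsulfamoyl on an aromatic carbon. Going by the values given here, no measured step covers this exact exchange. The closest guide is a 7.9-fold higher number from compound 1 to compound 3 (0.90 log units; beyond the scatter), which shows what the methylsulfamoyl group costs relative to hydrogen at that position, alongside a 3.4-fold higher number from compound 1 to compound 2 (0.53 log units; beyond the scatter), where methylsulfonyl costs somewhat less. Taking the methylsulfamoyl group away in favour of the much smaller amino group is therefore expected to move compound 4 back toward compound 1, though amino is not hydrogen and a full return cannot be assumed. Compound 4 is expected to give a lower number than its parent, a 5.0-fold lower number from compound 3 to compound 4 (0.70 log units; beyond the scatter), with an estimated value of 600 nM and a range from 200 nM to 2000 nM.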

Compound 4, inhibition constant: 260 nM
The estimate for compound 4 lay 2.3-fold (0.36 log units) above the measured number; measured number inside the range.
By their numbers in this assay, from the lowest: compounds 4 and 1 (each within the scatter of the next); then compound 2; then compound 3.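

In this assay, going by these compounds alone, compound 4 is the first case in which a group on this aromatic carbon brings no loss that can be told from the scatter, with a 1.5-fold lower number from compound 1 to compound 4 (0.16 log units; within the scatter), so the amino group and hydrogen cannot be separated here. The earlier compounds shown here showed only rises in the number at this position, and they left it unclear whether any group placed there would carry a cost; this result shows that the cost depends on the group, since the exchange gives a 5.0-fold lower number from compound 2 to compound 4 (0.70 log units; beyond the scatter) against methylsulfonyl and the large 12-fold lower number from compound 3 to compound 4 (1.06 log units; beyond the scatter) against methylsulfamoyl. Nothing available here explains why the amino group differs from the two sulfur-bearing groups at this carbon.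

The compounds shown leave open whether the amino group's result extends to close relatives on the same carbon, such as a methylamino, a dimethylamino or an acetamido group, or to a hydroxyl group. They also leave open how a carboxylic acid or a longer chain ending in an amine would behave at this position on the shared core.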